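Three Analogues on a Shared Core: Cytotoxicity in Vero Cells

The source may report more compounds than this note shows. Statements on the series, on what has been measured and on what is new or still open speak of the compounds shown alone.

Measured compounds:
compound 1, `C=CCOc1cc(OC)c(C(=O)/C=C/c2ccncc2)c(OCC=C)c1`: in an ADME assay on Vero cells (Chlorocebus sabaeus) for cytotoxicity, read by MTT assay (on this read-out higher numbers stand for weaker inhibition and lower numbers for stronger inhibition), compound 1 gives 2800 nM
compound 2, `C=CCOc1cc(OC)c(C(=O)/C=C/C=C/c2ccccc2)c(OCC=C)c1`: in this assay compound 2 gives "not determined" (no result reported)

For the measured compounds named here, compound 2 stands without a number: no result was reported for it in this assay, so nothing can be said of where it sits against compound 1, whose value in this assay is the only measurement in hand. The step to the unmeasured compound 3, `C=CCOc1cc(OC)c(C(=O)/C=C/c2ccc(Cl)cc2)c(OCC=C)c1`, changes the group on a double-bonded chain carbon bound to a double-bonded chain carbon: 4-chlorophenyl in place of 2-phenylethenyl on a double-bonded chain carbon bound to a double-bonded chain carbon. The 2-phenylethenyl group leaves and a 4-chlorophenyl group enters, the carbon count shrinking by one and a chlorine arriving, with no change in donors, acceptors or charge.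

Going by the values given here, with no value for compound 2 and no computed step joining it to compound 3, the direction of this step in this assay cannot be anchored; the expectation is that it stays within the usual scatter of repeated measurements. Among the compounds with values here, compound 3 is therefore expected to give about 3000 nM in this assay, estimated between 800 nM and 12000 nM, resting on the single value of compound 1 in this assay.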

Compound 3, half-maximal inhibitory concentration: 10400 nM
Compound 3: middle estimate off by 3.5-fold (0.54 log units), on the low side; low and high end bracket the measured number.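

In this assay the read-out shows a 3.7-fold higher number from compound 1 to compound 3 (0.57 log units; beyond the scatter) when 4-chlorophenyl replaces pyridin-4-yl on a double-bonded chain carbon bound to a double-bonded chain carbon. For the compounds shown here, this is the first readable comparison at this position, and it shows that a change of group here can carry the number beyond the usual scatter, though only modestly and towards weaker inhibition. The step between compound 2 and compound 3, with 4-chlorophenyl in place of 2-phenylethenyl, cannot be read, and nothing at hand explains the step that can be read.

The compounds shown leave open where the 2-phenylethenyl group of compound 2 would fall relative to the other two groups in this read-out. They also leave open how much of the step belongs to the chlorine and how much to the loss of the ring nitrogen, a question that a plain phenyl group at the same place would address, while a carboxylic acid or an amine there would test whether the trend extends beyond these aromatic groups.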